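The source may report more compounds than this note shows. Statements on the series, on what has been measured and on what is new or still open speak of the compounds shown alone.

Three compounds share one core. Compound 1 `Cc1ncc2c(N)c(C#N)c(N)nc2n1` carries a methyl group on that core, while compound 2 `CCCCc1nc(C(C)(C)C)nc2nc(N)c(C#N)c(N)c12` carries a butyl group and a tert-butyl group. In a physicochemical assay for solubility, in phosphate buffer, with a stated time of 18 h (on this read-out higher numbers stand for higher solubility and lower numbers for lower solubility), compound 1 gives 783000 nM, and in this assay compound 2 gives 6000 nM. Among the two measured numbers compound 2 stands lowest, and the gap to compound 1 lies well beyond the usual scatter, so compound 2 is clearly the less soluble of the pair.

Compound 3 `Cc1c[nH]c(-c2nc(C(C)(C)C)nc3nc(N)c(C#N)c(N)c23)n1` has not yet been measured. It differs from compound 2 at a single place: 4-methyl-1H-imidazol-2-yl in place of butyl on an aromatic carbon. The change swaps a plain chain for a small aromatic ring that brings one hydrogen-bond donor and one hydrogen-bond acceptor.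

Within the data shown here, no measured pair in this set tells how such a swap shifts solubility, so the expectation rests on the structural change alone. A modest rise from compound 2 is expected, a 3.3-fold higher number from compound 2 to compound 3 (0.52 log units; beyond the scatter), because compound 2 gives 6000 nM and the added ring replaces a chain with no donors or acceptors. For compound 3 the estimated solubility is 20000 nM, with a likely range from 5000 nM to 80000 nM.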

Compound 3, solubility: 5000 nM
The estimate for compound 3 lay 4.0-fold (0.60 log units) above the measured number; the measured number falls inside the stated range.
By their numbers in this assay, from the lowest: compounds 3 and 2 (each within the scatter of the next); then compound 1.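

Among these compounds, this is the first comparison in the set between two compounds that differ in one place, on an aromatic carbon opposite the ring nitrogen. In this assay, putting 4-methyl-1H-imidazol-2-yl in place of butyl gives a 1.2-fold lower number from compound 2 to compound 3 (0.08 log units; within the scatter) and leaves compound 2 and compound 3 indistinguishable on this read-out, even though the entering group adds a five-membered aromatic ring with 1 hydrogen-bond donor and 1 hydrogen-bond acceptor, where butyl has neither. Nothing measured here explains why the two numbers stay so close.

The compounds shown leave open whether another group at this place, such as an amine, a carboxylic acid or a longer chain, would shift the number beyond the scatter. They also leave open whether this swap would give a similar result with something other than the tert-butyl group elsewhere on the shared core, and compound 1 cannot settle that, as it differs from compound 2 and compound 3 in more than one place.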